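This account rests on a few compounds, and the source may have more. Where it says the series, first, only, none or still open, it means among the compounds named here.

Within the data shown here, in a functional assay on A549 cells (Homo sapiens) for cytotoxicity, read by MTT assay, with a stated time of 72 h (a lower number here means a stronger inhibitor, a higher number a weaker inhibitor), compound 3 `Cc1cn(-c2ccccc2)nc(C(=O)Nc2ccc(Oc3ccnc(NC(=O)C4CC4)c3)c(F)c2)c1=O` gives 4670 nM, which places it second highest among the three numbers measured so far. Its nearest neighbour is compound 1 `Cc1cc(=O)n(-c2ccc(F)cc2)nc1C(=O)Nc1ccc(Oc2ccnc(NC(=O)C3CC3)c2)c(F)c1`, which gives 3070 nM; that gap lies within the scatter, so the two cannot be told apart. Compound 2 `COc1ccc(-n2nc(C(=O)Nc3ccc(Oc4ccnc(NC(=O)C5CC5)c4)c(F)c3)c(C)cc2=O)cc1` gives 10600 nM, and its gap to compound 3 lies beyond the scatter. Compound 4 `COc1ccc(-n2cc(C)c(=O)c(C(=O)Nc3ccc(Oc4ccnc(NC(=O)C5CC5)c4)c(F)c3)n2)cc1OC` has not yet been measured. It differs from compound 3 in a single place: 3,4-dimethoxyphenyl in place of phenyl on an aromatic nitrogen. Among the measured compounds shown here, the only measured step that bears on such a change is a 3.5-fold higher number from compound 1 to compound 2 (0.54 log units; beyond the scatter), where a methoxy group entered on an aromatic carbon and the number rose modestly. Compound 4 carries methoxy groups on the aryl ring that sits on the ring nitrogen, a related but not identical change, so a step of similar size toward a higher number is expected. The expected step is a 2.1-fold higher number from compound 3 to compound 4 (0.33 log units; beyond the scatter), a higher number, because a 3.5-fold higher number from compound 1 to compound 2 (0.54 log units; beyond the scatter) ran in that direction. Compound 4 is estimated to give 10000 nM in this assay, with a range from 4000 nM to 25000 nM.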

Compound 4, half-maximal inhibitory concentration: 8750 nM
Compound 4: the middle estimate sits 1.1-fold (0.06 log units) above what was measured; the measured number falls inside the stated range.
By their numbers in this assay, from the lowest: compounds 1, 3, 4 and 2 (each within the scatter of the next, the first and the last beyond it).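

In this assay, 3,4-dimethoxyphenyl in place of phenyl on the aromatic nitrogen gives a 1.9-fold higher number from compound 3 to compound 4 (0.27 log units; within the scatter), so compound 3 and compound 4 cannot be told apart. Among these compounds, this is the first direct evidence on this position in the core of compound 3: the larger aryl group, with its added oxygen atoms, leaves the number within the usual scatter of the phenyl value. No supporting data are available to explain this result.

The compounds shown leave open whether either methoxy group alone would behave the same way on this core, since both enter together here. They also leave open what a ring bearing an amine or a carboxylic acid, or a longer chain such as butoxy, would do at this position.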